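Bis-chalcone series: aryl substituent change at the fourth position

The source may report more compounds than this note shows. Statements on the series, on what has been measured and on what is new or still open speak of the compounds shown alone.

Measured so far:
compound 1 `Cc1cc(O)c(C(=O)/C=C/c2ccc(F)cc2)c(-c2ccccc2)c1C(=O)/C=C/c1ccc(F)cc1` — 20000 nM
compound 2 `Cc1cc(O)c(C(=O)/C=C/c2ccc(F)cc2)c(-c2ccc(Br)cc2)c1C(=O)/C=C/c1ccc(F)cc1` — 22300 nM
compound 3 `COc1ccc(/C=C/C(=O)c2c(C)cc(O)c(C(=O)/C=C/c3ccc(OC)cc3)c2-c2ccc(Br)cc2)cc1` — "not active" (no number reported)

Compound 2 `Cc1cc(O)c(C(=O)/C=C/c2ccc(F)cc2)c(-c2ccc(Br)cc2)c1C(=O)/C=C/c1ccc(F)cc1` sits at the higher of the two numbers obtained in a functional assay on MDA-MB-231 cells (Homo sapiens) for cytotoxicity, read by MTT assay, with a stated time of 24 h (on this read-out higher numbers stand for weaker inhibition and lower numbers for stronger inhibition), where compound 2 gives 22300 nM. Its nearest neighbour is compound 1, and the step of a 1.1-fold higher number from compound 1 to compound 2 (0.05 log units; within the scatter) lies within the scatter, so the two numbers cannot be told apart. Compound 3 carries no number in this assay and is reported only as inactive.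

Compound 4 `Cc1cc(O)c(C(=O)/C=C/c2ccc(F)cc2)c(-c2ccc(OCc3ccccc3)cc2)c1C(=O)/C=C/c1ccc(F)cc1` differs from compound 2 in one place: benzyloxy in place of bromo on an aromatic carbon. Within the data shown here, the only measured step that touches this position is the one from compound 1 to compound 2, which exchanged hydrogen for bromo and moved the number a 1.1-fold higher number from compound 1 to compound 2 (0.05 log units; within the scatter), within the scatter. Among the measured compounds shown here, no measured pair shows a benzyloxy at this position, so the size of the new group has no precedent here. For the measured compounds named here, on the single step available, a change at this aromatic carbon has not shifted the read-out beyond the scatter, and the same is expected for compound 4: a step of about a 1.0-fold lower number from compound 2 to compound 4 (0.01 log units; within the scatter) in this assay, with no direction that can be distinguished from noise. Compound 4 is therefore expected to give about 22000 nM in this assay, with a range from 8000 nM to 60000 nM.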

Compound 4, half-maximal inhibitory concentration: 15000 nM
For compound 4 the middle estimate is 1.5-fold (0.17 log units) above the measured one, within the range that was stated.
By their numbers in this assay, from the lowest: compounds 4, 1 and 2 (each within the scatter of the next).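

At this aromatic carbon, the series now spans a far larger group: benzyloxy, with 8 heavy atoms and one six-membered aromatic ring, replaces bromo, with 1 heavy atom, and gives a 1.5-fold lower number from compound 2 to compound 4 (0.17 log units; within the scatter) in this assay without a step beyond the scatter. Against hydrogen at the same carbon, benzyloxy gives a 1.3-fold lower number from compound 1 to compound 4 (0.12 log units; within the scatter) and this step also stays within the scatter, so hydrogen, bromo and benzyloxy cannot be told apart at this position in the three compounds with numbers. No measurement is available that would explain why the numbers stay together here.

From the compounds shown here alone, it remains open whether any group at this aromatic carbon can move the number beyond the scatter, for example an amine, a carboxylic acid or a longer chain ending in a hydroxyl group. Going by these compounds, it is also open whether the same insensitivity to the group at this carbon would hold if the shared core carried different groups elsewhere, since all three steps were read on a single background.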